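The compounds below may be only part of what the source reports. "The series", "measured", "known", "first", "only" and "open" are said of these compounds alone.

Compound 1, `CCCc1nc2ccccc2c(=O)n1/N=C/c1ccc(Oc2ccc3ccccc3c2)cc1` — a physicochemical assay for lipophilicity, in phosphate buffer, measured as octanol-water partition; a lower number here means a more polar compound, a higher number a more lipophilic compound: 6.12
Compound 2, `CCCc1nc2ccccc2c(=O)n1/N=C/c1ccc(Oc2ccc(F)cc2)cc1` — this assay: 5.22

Of the compounds shown here, two sharing the same core have been measured so far. Going by the values given here, of the two, compound 2 has the lower partition coefficient; its only neighbour is compound 1, and the step of a number 0.90 log units lower from compound 1 to compound 2 (beyond the scatter) lies beyond the scatter. Compound 3, `CCCc1nc2ccccc2c(=O)n1/N=C/c1ccc(Oc2ccc([N+](=O)[O-])cc2)cc1`, has not yet been measured. It differs from compound 2 in a single place: nitro in place of fluoro on an aromatic carbon. Among the compounds with values here, the one measured step, from compound 1 to compound 2, also concerns the group carried on the oxygen of the shared phenoxy ring, but it exchanged a naphthalen-2-yl for a 4-fluorophenyl, which is a larger change than the present one. Nothing measured here mirrors a nitro in place of a fluoro directly, so the expectation rests on general experience with such exchanges rather than on a matching step. The author expects a small downward shift, a number 0.42 log units lower from compound 2 to compound 3 (beyond the scatter), for compound 3. The estimate for compound 3 in this assay is therefore 4.8, with a range from 4.4 to 5.2.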

Compound 3, partition coefficient: 5.18
Compound 3: the middle estimate sits 0.38 log units below what was measured, and the stated range covers the measured number.
By their numbers in this assay, from the lowest: compounds 3 and 2 (each within the scatter of the next); then compound 1.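

Going by these compounds alone, at this place, on an aromatic carbon para to a large group, the exchange of fluoro for nitro gives a number 0.04 log units lower from compound 2 to compound 3 (within the scatter) in this assay and so does not separate the two groups by this read-out, which the single earlier step could not show. Compound 3 also gives a number 0.94 log units lower from compound 1 to compound 3 (beyond the scatter) and, read beside a number 0.90 log units lower from compound 1 to compound 2 (beyond the scatter) this means that both the 4-fluorophenyl and the 4-nitrophenyl group in place of naphthalen-2-yl give a step beyond the scatter in the same direction, with neither compound going against that pattern among the three compounds shown. Nothing available accounts for these results.

Going by these compounds, it remains open whether other groups at this place, such as an amine, a carboxylic acid or a longer chain, would also stay within the scatter of compound 2 or would move the number beyond it. On these data alone, it is equally open whether fluoro and nitro at this place would stay this close in any read-out other than the partition coefficient.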